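Shifting the amide aryl from 2,5-dimethylphenyl to 4-fluorophenyl

The source may hold more compounds than are shown below. What is called first, only, known or untested is meant among the compounds shown, and "the series" means these compounds.

Compound 1 `Cc1ccc(C)c(NC(=O)CSc2nnc(-c3ccoc3C)n2Cc2ccco2)c1`: > 15800 nM
Compound 2 `Cc1occc1-c1nnc(SCC(=O)Nc2ccc(F)c(Cl)c2)n1Cc1ccco1`: 1000 nM
Compound 3 `Cc1cccc(NC(=O)CSc2nnc(-c3ccoc3C)n2Cc2ccco2)c1`: 2510 nM

In a functional assay on CHO cells for antagonist activity at Orexin/Hypocretin receptor type 1 (Homo sapiens), read by FLIPR and calcium flux (a higher number here means a weaker inhibitor, a lower number a stronger inhibitor), compound 1 gives only a limit of the assay, > 15800 nM, so its true number is not known; it sits at the limit of > 15800 nM in this assay, at which 1 of the 3 values shown sits. Compound 2 gives 1000 nM and compound 3 gives 2510 nM in the same assay.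

Compound 4 `Cc1occc1-c1nnc(SCC(=O)Nc2ccc(F)cc2)n1Cc1ccco1` has not been measured. It differs from compound 1 in one place (4-fluorophenyl in place of 2,5-dimethylphenyl on an amide-type nitrogen).

Two measured steps start from the same compound 1 and change the same group. Replacing 2,5-dimethylphenyl with 3-chloro-4-fluorophenyl gave an at least 15-fold lower number from compound 1 to compound 2 (1.19 log units; beyond the scatter), and dropping the methyl on an aromatic carbon to reach 3-methylphenyl gave an at least 6.2-fold lower number from compound 1 to compound 3 (0.79 log units; beyond the scatter). Between those two aryl groups, moving from 3-chloro-4-fluorophenyl to 3-methylphenyl gave a 2.5-fold higher number from compound 2 to compound 3 (0.40 log units; beyond the scatter). Every departure from the 2,5-dimethylphenyl of compound 1 shown here has lowered the number beyond the scatter, so a lower number is expected for compound 4 too, though since compound 1 is only a limit the size of the step cannot be fixed. The estimated step is an at least 3.9-fold lower number from compound 1 to compound 4 (0.59 log units; beyond the scatter). Compound 4 is expected to give about 4000 nM, within a range of 1500 nM to 12000 nM.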

Compound 4, inhibition constant: > 15800 nM
Compound 4 gave a limit, no number (the forecaster's own chance of this, stated with the estimate: 25%); middle value at least 3.9-fold (0.59 log units) from the limit.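

Compound 4 breaks the pattern set by compound 2 and compound 3, in which every departure from the 2,5-dimethylphenyl of compound 1 lowered the number: a change at this amide-type nitrogen does not lower it on its own, and what enters decides the outcome. Hydrogen in place of chloro on an aromatic carbon gave an at least 15-fold higher number from compound 2 to compound 4 (1.19 log units; beyond the scatter), and 4-fluorophenyl in place of 3-methylphenyl gave an at least 6.2-fold higher number from compound 3 to compound 4 (0.79 log units; beyond the scatter), so the fluorine of 4-fluorophenyl is not enough to keep the number of either compound 2 or compound 3 in this assay. The steps that start from compound 1 cannot be read for compound 4 because both ends are limits, and compound 1 and compound 4 therefore cannot be ordered against each other: the limit of > 15800 nM in this assay, at which 2 of the 4 values shown sit.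

Whether chloro alone would keep the number near that of compound 2 remains open, since a 3-chlorophenyl group does not stand among these compounds. Also open, from the compounds shown here alone, is whether a 3-bromo-4-fluorophenyl or a 3-methoxyphenyl group on the same amide-type nitrogen would lower the number further.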